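A few compounds are considered here, and "the series" means these few. Any claim that something is new, unique, unknown or untested is made for them only; others in the source may bear on it.

Compound 1, `CNC(=S)N1CC(C)C(c2ccc(C)cc2)=N1`, gives 40% in an in vitro assay on cells for inhibition of Amine oxidase [flavin-containing] A (Homo sapiens), read by Amplex Red, with a stated time of 15 min, tested at 100 uM; on this read-out higher numbers stand for more inhibition at the one concentration tested (going by the name of the read-out) and lower numbers for less inhibition. Compound 2, `CNC(=S)N1CC(C)C(c2ccccc2)=N1`, gives "not active" (no number reported) in this assay, reported as inactive with no number given.

Compound 2 therefore stands without a single number in this assay; all that the two values show is that compound 1 inhibits measurably while compound 2 does not. Compound 3, `CNC(=S)N1CC(C)C(c2ccc(Cl)cc2)=N1`, differs from compound 2 by chloro in place of hydrogen on an aromatic carbon. Going by the values given here, no measured step of this kind exists, yet an upward move in this assay is expected because compound 1 with a group at that same carbon gives 40%. Compound 3 is expected to reach about 35%, estimated between 10% and 65%.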

Compound 3, a percentage reported as inhibition, at one concentration (the size of the read-out at that concentration, not a potency): "not active" (no number reported)
Compound 3 has no reported number here; there is nothing to compare the estimate with.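

In this assay, going by these compounds alone, compound 2 and compound 3 both lack a number, so no step between them can be read. Left open is whether chloro in place of hydrogen changes inhibition at all. No measurement shown bears on this result.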